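Aryloxy change on the shared core of compound 3

The compounds below may be only part of what the source reports. "The series", "measured", "known", "first", "only" and "open" are said of these compounds alone.

Among the compounds with values here, compound 3, `CC(C)(Oc1ccc(F)cc1)C1OCC(C/C=C\CCC(=O)O)C(c2cccnc2)O1`, is the only member of the series with a measured number: in an assay for inhibition of prostacyclin synthase (Homo sapiens), using microsomes (on this read-out higher numbers stand for weaker inhibition and lower numbers for stronger inhibition), compound 3 gives 2000 nM. Compound 1, `N#Cc1ccc(C2OCC(C/C=C\CCC(=O)O)C(c3cccnc3)O2)cc1`, reaches only a limit of the assay, > 100000 nM in this assay. Compound 2, `N#Cc1ccccc1C1OCC(C/C=C\CCC(=O)O)C(c2cccnc2)O1`, likewise stops at a limit, > 100000 nM in this assay. Within the data shown here, the one step between measured compounds, a step that the two limits leave unreadable from compound 1 to compound 2, carries no size, as the limit of > 100000 nM in this assay, at which 2 of the 3 values shown sit, places both ends of it at the same limit.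

Compound 4, `CC(C)(Oc1ccccc1Br)C1OCC(C/C=C\CCC(=O)O)C(c2cccnc2)O1`, differs from compound 3 in one place: 2-bromophenyl in place of 4-fluorophenyl on an oxygen on a saturated carbon. Among the measured compounds shown here, no measured step bears directly on this change; the unreadable step concerns a cyanophenyl group on a saturated ring carbon, not an aryl group on an oxygen, and its two limits give no size. With nothing to anchor a direction, the expected step of no change at the digits printed from compound 3 to compound 4 (within the scatter) is none beyond the scatter, though the uncertainty is wide. Compound 4 is estimated at 2000 nM in this assay, within 400 nM to 12000 nM.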

Compound 4, half-maximal inhibitory concentration: 7000 nM
For compound 4 the middle estimate is 3.5-fold (0.54 log units) below the measured one; the measured number falls inside the stated range.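

In this assay, within the data shown here, 2-bromophenyl in place of 4-fluorophenyl on the oxygen gives a 3.5-fold higher number from compound 3 to compound 4 (0.54 log units; beyond the scatter), the first step with a readable size. The cyanophenyl change on the saturated ring carbon offered no such reading, since its step cannot be read. Here both ends of the change keep a number, so the aryl group on this oxygen can be changed without the value reaching the assay limit, at least for this one pair. Nothing among the data shown accounts for the size of this step.

From the compounds shown here alone, the step changes the halogen and its place on the phenyl ring together, so what 2-fluorophenyl or 4-bromophenyl would read on this oxygen remains open. Also open, going by these compounds, is how an amine or a carboxylic acid on this phenyl ring would read.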